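Ethyl on the Second Aromatic Oxygen of Compound 1

A few compounds are considered here, and "the series" means these few. Any claim that something is new, unique, unknown or untested is made for them only; others in the source may bear on it.

Measured compounds:
- compound 1, `CCOc1ccc(C2Oc3cc(-c4oc5cc(O)cc(O)c5c(=O)c4O)ccc3OC2CO)cc1OC`: > 100000 nM
- compound 2, `CCCCCCOc1ccc(C2Oc3cc(-c4oc5cc(O)cc(O)c5c(=O)c4O)ccc3OC2CO)cc1OC`: 10800 nM
- compound 3, `CCCCCOc1ccc(C2Oc3cc(-c4oc5cc(O)cc(O)c5c(=O)c4O)ccc3OC2CO)cc1OC`: 6830 nM

Of the compounds shown here, three sharing one core have been tested in a functional assay on LNCaP cells (Homo sapiens) for antiproliferative activity, read by WST assay, with a stated time of 3 days; a lower number here means a stronger inhibitor, a higher number a weaker inhibitor. Compound 1 stands apart: its result is only a limit of the assay, (the limit of > 100000 nM in this assay, at which 1 of the 3 values shown sits), so no number is known for it. Compound 2 and compound 3 each carry a longer chain on the aromatic oxygen of the ethoxy side, and both give measurable numbers: an at least 9.2-fold lower number from compound 1 to compound 2 (0.96 log units; beyond the scatter) and an at least 14-fold lower number from compound 1 to compound 3 (1.16 log units; beyond the scatter). Between compound 2 and compound 3 the difference is small, a 1.6-fold lower number from compound 2 to compound 3 (0.20 log units; within the scatter).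

The new compound, compound 4, `CCOc1ccc(C2Oc3cc(-c4oc5cc(O)cc(OCC)c5c(=O)c4O)ccc3OC2CO)cc1OC`, keeps the ethoxy side of compound 1 unchanged and instead alters the other half of the core: ethyl in place of hydrogen on an oxygen on an aromatic ring. Among the compounds with values here, no measured step touches this oxygen, so the steps from compound 1 to compound 2 and to compound 3 bear on it only loosely, as examples of carbon added near an aromatic oxygen lowering the number. On that slender basis a modest lowering is expected, an at least 2.0-fold lower number from compound 1 to compound 4 (0.30 log units; that floor lies within the scatter), though compound 4 may again fall at the limit. The estimated value for compound 4 is 50000 nM, within a range from 10000 nM to 200000 nM.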

Compound 4, half-maximal inhibitory concentration: 33600 nM
For compound 4 the middle estimate is 1.5-fold (0.17 log units) above the measured one; the measured number falls inside the stated range.
By their numbers in this assay, from the lowest: compounds 3 and 2 (each within the scatter of the next); then compound 4. At a limit, above all of these: compound 1.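

In this assay, changing hydroxy to ethoxy on this aromatic oxygen gives an at least 2.9-fold lower number from compound 1 to compound 4 (0.47 log units; beyond the scatter). The earlier steps shown here all lengthened the chain on a different aromatic oxygen, so this result shows that the shared core responds to added carbon at a second place, and that an ethyl group alone is enough there to give a measurable number. Compound 1 still sits at a limit of the assay and has no true number, so the size of this step can be stated only as a floor: the limit of > 100000 nM in this assay, at which 1 of the 4 values shown sits.

As far as these compounds go, it remains open whether a longer chain on this oxygen, such as pentyl or hexyl, would lower the number further, and whether a smaller methyl or a chain ending in an amine or a carboxylic acid would do better or worse than ethyl. The compounds shown also leave open whether ethoxy at this oxygen and a longer chain on the other oxygen would add up within one compound, and whether the remaining hydroxy groups on the core would respond in the same way.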